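The source may hold more compounds than are shown below. What is called first, only, known or untested is meant among the compounds shown, and "the series" means these compounds.

Of the compounds shown here, three built on one shared core have been measured in a functional assay on HT-1080 cells (Homo sapiens), read by transwell migration, with a stated time of 24 h, tested at 1 uM; on this read-out lower numbers stand for a stronger effect and higher numbers for a weaker effect at the one concentration tested. Compound 1 `CC(=O)OCc1ccc2oc(=O)c(C(=O)Oc3cccc(Cl)c3)cc2c1` gives 49.1%. Among the compounds with values here, compound 2 `CC(=O)OCc1ccc2oc(=O)c(C(=O)Sc3cccc(Cl)c3)cc2c1` gives 65.8%, and the step of a number 16.7 percentage points higher from compound 1 to compound 2 (beyond the scatter) is the only single-point change measured so far. Compound 3 `CCCCCC(=O)OCc1ccc2oc(=O)c(C(=O)Oc3cccc(Br)c3)cc2c1` gives 59.3%; on these numbers it stands second highest of the three, within the scatter of compound 2 and beyond the scatter above compound 1.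

Compound 4 `CC(=O)NCc1ccc2oc(=O)c(C(=O)Oc3cccc(Br)c3)cc2c1` has not yet been measured. The change from compound 3 is acetamido in place of (pentylcarbonyl)oxy on a saturated chain carbon bound to an aromatic carbon. Within the data shown here, no measured step touches this part of the molecule: the one known step concerns the group on the carbonyl carbon and was modest, so it gives no direct guidance here. The expectation for compound 4 therefore rests on the spread of the three values alone, and a step of no more than that spread, in either direction, is expected. Compound 4 is estimated at 58%, within the range 40% to 76%. The step of a number 1.3 percentage points lower from compound 3 to compound 4 (within the scatter) is expected to stay within the usual scatter.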

Compound 4, a percentage reported as activity, at one concentration (the size of the read-out at that concentration, not a potency): 36.9%
Compound 4: middle estimate off by 21.1 percentage points, on the high side; measured number outside the range, below it.
By their numbers in this assay, from the lowest: compound 4; then compound 1; then compounds 3 and 2 (each within the scatter of the next).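

In this assay, within the data shown here, putting acetamido in place of (pentylcarbonyl)oxy on a saturated chain carbon bound to an aromatic carbon gives a number 22.4 percentage points lower from compound 3 to compound 4 (beyond the scatter) and so shows, for the first time, that this position can change the read-out, here towards a stronger effect at the one concentration tested. The swap alters several things at once: the group entering has 4 heavy atoms against 8 in the group leaving, it carries a nitrogen, and it brings 1 hydrogen-bond donor where the other has none. Nothing measured here explains why the number changes.

Which of these differences matters stays open. A hexanamido group, which would keep the longer chain while also bringing in the nitrogen, or a plain amine at this place could begin to separate them.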